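The compounds below may be only part of what the source reports. "The series", "measured", "known", "first", "only" and "open" are said of these compounds alone.

Measured compounds:
compound 1 `OC1CCC(Nc2nc(-c3ccccc3)nc3c2nnn3Cc2ccccc2F)CC1` with 1850000 nM
compound 2 `CCCNc1nc(-c2ccccc2)nc2c1nnn2Cc1ccccc1F` with 3200000 nM
compound 3 `CNc1nc(-c2ccccc2)nc2c1nnn2Cc1ccccc1F` with 25000000 nM

Three compounds share one core and differ only in the group on the amine nitrogen. In an assay on isolated protein for binding affinity to adenosine receptor A1 (Bos taurus) (a higher number here means a weaker inhibitor, a lower number a stronger inhibitor), compound 3 gives the highest of the three numbers: a 7.8-fold higher number from compound 2 to compound 3 (0.89 log units; beyond the scatter) and a 14-fold higher number from compound 1 to compound 3 (1.13 log units; beyond the scatter) both lie beyond the scatter, so compound 3 is the weakest of the set. Compound 1 and compound 2 sit within the scatter of each other, as a 1.7-fold higher number from compound 1 to compound 2 (0.24 log units; within the scatter) shows.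

The next compound, compound 4 `CCCCNc1nc(-c2ccccc2)nc2c1nnn2Cc1ccccc1F`, is reached from compound 3 by propyl in place of hydrogen on a saturated chain carbon bound to a nitrogen on an aromatic ring. Going by the values given here, only one measured step speaks to lengthening this chain: the change from compound 2 to compound 3 ran the other way, shortening propyl to methyl, and gave a 7.8-fold higher number from compound 2 to compound 3 (0.89 log units; beyond the scatter). The larger replacement in a 14-fold higher number from compound 1 to compound 3 (1.13 log units; beyond the scatter) points the same way. Going from methyl to butyl is therefore expected to lower the number by a modest amount, roughly like propyl, with a 10-fold lower number from compound 3 to compound 4 (1.00 log units; beyond the scatter) expected. For compound 4 the estimate in this assay is 2500000 nM, with a range from 700000 nM to 8000000 nM.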

Compound 4, inhibition constant: 4300000 nM
For compound 4 the middle estimate is 1.7-fold (0.24 log units) below the measured one; the range from low to high includes it.
By their numbers in this assay, from the lowest: compounds 1, 2 and 4 (each within the scatter of the next, the first and the last beyond it); then compound 3.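

In this assay the gain from lengthening the chain on the amine nitrogen also holds for butyl, with a 5.8-fold lower number from compound 3 to compound 4 (0.76 log units; beyond the scatter) as the step from the methyl compound. The further carbon beyond propyl brings no readable change, as a 1.3-fold higher number from compound 2 to compound 4 (0.13 log units; within the scatter) shows, yet a 2.3-fold higher number from compound 1 to compound 4 (0.37 log units; beyond the scatter) separates the butyl compound from the 4-hydroxycyclohexyl compound, a gap that the propyl compound, still within the scatter of compound 1, did not open. No supporting evidence is available to explain these steps.

Going by these compounds, it remains open whether a longer chain such as pentyl or hexyl would change the number, or whether a branched chain such as isopropyl would match the straight ones. On these data alone, it is also open whether a plain cyclohexyl would give a number like that of compound 1, which would separate the part played by the ring from that of the hydroxyl.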